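Replacing bromo with fluoro: the step to compound 4

The compounds below may be only part of what the source reports. "The series", "measured", "known", "first", "only" and "open" are said of these compounds alone.

In a functional assay on LOX IMVI cells (Homo sapiens) for cytotoxicity, read by MTT assay, with a stated time of 24 h (a higher number here means a weaker inhibitor, a lower number a stronger inhibitor), compound 1 `COc1cc(-c2nc(-c3ccccc3)[nH]c2-c2ccnc(NCCCNS(=O)(=O)c3ccccc3)n2)ccc1F` gives 4520 nM, compound 2 `COc1cc(-c2nc(-c3ccccc3)[nH]c2-c2ccnc(NCCCNS(=O)(=O)c3ccc(Cl)cc3)n2)ccc1F` gives 83100 nM and compound 3 `COc1cc(-c2nc(-c3ccccc3)[nH]c2-c2ccnc(NCCCNS(=O)(=O)c3ccc(Br)cc3)n2)ccc1F` gives 33900 nM, the second highest of the three numbers. Compound 4 `COc1cc(-c2nc(-c3ccccc3)[nH]c2-c2ccnc(NCCCNS(=O)(=O)c3ccc(F)cc3)n2)ccc1F` carries fluoro in place of bromo on an aromatic carbon, para to a large group: fluoro in place of bromo on an aromatic carbon. Chloro in place of hydrogen gave an 18-fold higher number from compound 1 to compound 2 (1.26 log units; beyond the scatter), bromo in place of hydrogen gave a 7.5-fold higher number from compound 1 to compound 3 (0.88 log units; beyond the scatter), and bromo in place of chloro gave a 2.5-fold lower number from compound 2 to compound 3 (0.39 log units; beyond the scatter). Among the measured compounds shown here, no fluoro compound has been measured, so the reasoning is loose, but compound 4 is expected to fall between compound 1 and compound 3. The expected change is a 2.3-fold lower number from compound 3 to compound 4 (0.35 log units; beyond the scatter), a modest one. For compound 4 the estimated value is 15000 nM, with an expected range of 3500 nM to 60000 nM.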

Compound 4, half-maximal inhibitory concentration: 3960 nM
Compound 4: middle estimate off by 3.8-fold (0.58 log units), on the high side, within the range that was stated.
By their numbers in this assay, from the lowest: compounds 4 and 1 (each within the scatter of the next); then compound 3; then compound 2.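

In this assay, halogens at this place do not behave alike: fluoro in place of bromo gives an 8.6-fold lower number from compound 3 to compound 4 (0.93 log units; beyond the scatter), and fluoro in place of chloro gives a 21-fold lower number from compound 2 to compound 4 (1.32 log units; beyond the scatter). Fluoro in place of hydrogen gives a 1.1-fold lower number from compound 1 to compound 4 (0.06 log units; within the scatter), so only chloro and bromo, not every halogen, move the number away from that of the unsubstituted ring. Nothing available explains this split among the halogens. From the compounds shown here alone, whether methoxy, an amine or a carboxylic acid on the same aromatic carbon would lower the number beyond compound 1 and compound 4, or raise it as chloro and bromo do, remains open.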